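Moving the fluorine on the aryl ring of the ethenyl chain

The compounds below may be only part of what the source reports. "The series", "measured", "known", "first", "only" and "open" are said of these compounds alone.

Compound 1 `COC(=O)/C=C/c1cccc(N(Cc2ccc(/C=C/c3c(F)cccc3F)cc2)C(=O)C(C)C)c1` gives 108 nM in an assay on isolated protein with Bile acid receptor (Homo sapiens) as the target; a lower number here means that less compound is needed, a higher number that more compound is needed for the effect.
Compound 2 `COC(=O)/C=C/c1cccc(N(Cc2ccc(/C=C/c3ccccc3F)cc2)C(=O)NC(C)C)c1` gives 431 nM in this assay.

Compound 1 holds the lower of the two measured numbers, and compound 2 stands above it by a gap that lies beyond the usual scatter. Among the compounds with values here, compound 2 differs from compound 1 in two places at once, so the two values show only that the pair is separated, not which change carries the separation.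

Compound 3 `COC(=O)/C=C/c1cccc(N(Cc2ccc(/C=C/c3ccc(F)cc3)cc2)C(=O)C(C)C)c1` differs from compound 1 in one place: 4-fluorophenyl in place of 2,6-difluorophenyl on a double-bonded chain carbon bound to a double-bonded chain carbon. Within the data shown here, no single-place step between measured compounds is available to anchor this change. The step from compound 1 to compound 3 in this assay is expected to be small, a 2.0-fold higher number from compound 1 to compound 3 (0.31 log units; beyond the scatter), toward a higher number, and may well fall inside the scatter. Compound 3 is therefore estimated at 220 nM, with a range from 70 nM to 700 nM.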

Compound 3, half-maximal effective concentration: 120 nM
Compound 3: the middle estimate sits 1.8-fold (0.26 log units) above what was measured; the range from low to high includes it.
By their numbers in this assay, from the lowest: compounds 1 and 3 (each within the scatter of the next); then compound 2.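

Within the data shown here, this is the first comparison at this position in which only one place differs: in this assay, going from 2-(2,6-difluorophenyl)ethenyl to 2-(4-fluorophenyl)ethenyl gives a 1.1-fold higher number from compound 1 to compound 3 (0.05 log units; within the scatter). The two fluorinated aryl groups therefore cannot be told apart in this assay, with the rest of the core held the same, so the number of fluorines and their placement on the ring make no readable difference across this single pair. No supporting measurement bears on this result, which therefore stands as an observation only.

The compounds shown leave open whether this position accepts an unsubstituted phenyl, or a ring carrying a methoxy or a trifluoromethyl group instead of fluorine. They also leave open how a pyridine ring would read in place of the fluorinated phenyl ring on the same ethenyl chain.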